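The source may hold more compounds than are shown below. What is called first, only, known or untested is meant among the compounds shown, and "the series" means these compounds.

Compound 3 `COc1cc2oc(=O)n(CCC(=O)O)c2cc1Cl` is the point of departure. In a physicochemical assay for permeability, using PAMPA (a higher number here means that the compound crosses the layer faster, a lower number that the compound crosses the layer more slowly), compound 3 reaches only a limit of the assay, < 3 nm/s. Compound 2 `CCc1cc2oc(=O)n(CCC(=O)O)c2cc1Cl` likewise gives only a limit in this assay, < 10 nm/s. Compound 1 `O=C(O)CCn1c(=O)oc2cc(OCc3ccccc3)c(Cl)cc21` shows "not determined" (no result reported) in this assay. Going by the values given here, the single measured step, a step that the two limits leave unreadable from compound 2 to compound 3, stays unreadable because the limit of < 10 nm/s in this assay, at which 1 of the 3 values shown sits, and the limit of < 3 nm/s in this assay, at which 1 of the 3 values shown sits, bound both of its ends.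

Compound 4 `O=C(O)CCn1c(=O)oc2cc(Cl)c(Cl)cc21` differs from compound 3 by chloro in place of methoxy on an aromatic carbon. Among the compounds with values here, no measured step bears on this change, and the one step available carries no size. Compound 4 is therefore expected close to compound 3, at 3 nm/s, within 1 nm/s to 12 nm/s. The expected step, a number no lower from compound 3 to compound 4 (the limit leaves the size open), is estimated to fall within the usual scatter.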

Compound 4, apparent permeability: 24 nm/s
Estimate against measurement, compound 4: 8.0-fold (0.90 log units) below; measured number outside the range, above it.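

With chloro on this aromatic carbon, ortho to a chloro group, compound 4 is the only compound shown with a reading in this assay that is not a limit. Chloro in place of methoxy gives an at least 8.0-fold higher number from compound 3 to compound 4 (0.90 log units; beyond the scatter), and chloro in place of ethyl gives an at least 2.4-fold higher number from compound 2 to compound 4 (0.38 log units; beyond the scatter), so this position responds to both changes. The first of these sizes is only a floor, because compound 3 stands at a limit of the assay: the limit of < 3 nm/s in this assay, at which 1 of the 4 values shown sits.

From the compounds shown here alone, it remains open how fluoro, a nitrile or an amine on this carbon would read in this assay. Going by these compounds, it is also open whether chloro would give such a step on a core without the neighbouring chloro group.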